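The compounds below may be only part of what the source reports. "The series", "measured", "known", "first", "only" and "open" are said of these compounds alone.

The measured compounds:
compound 1 `O=C(Nc1cccnc1)c1ccccc1OCc1ccccc1Cl` gives 1100 nM in an assay on lysate for inhibition of phosphatidylcholine:ceramide cholinephosphotransferase 2 (Homo sapiens), read by HPLC, with stated times of 30 min and 2 h; on this read-out lower numbers stand for stronger inhibition and higher numbers for weaker inhibition
compound 2 `N#Cc1ccccc1COc1ccccc1C(=O)Nc1cccnc1` gives 31800 nM in this assay
compound 3 `Cc1ccc(F)cc1COc1ccccc1C(=O)Nc1cccnc1` gives 740 nM in this assay

Compound 3 has the lowest number of the three. Its gap to compound 1, a 1.5-fold lower number from compound 1 to compound 3 (0.17 log units; within the scatter), is within the scatter, so no order between these two is claimed; its gap to compound 2, a 43-fold lower number from compound 2 to compound 3 (1.63 log units; beyond the scatter), is large and beyond the scatter.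

Compound 4 `Cc1ccc(Cl)cc1COc1ccccc1C(=O)Nc1cccnc1` differs from compound 3 by chloro in place of fluoro on an aromatic carbon. Among the measured compounds shown here, no measured step swaps fluoro for chloro on that ring, so the bearing of the measured steps is indirect. The step of a 29-fold higher number from compound 1 to compound 2 (1.46 log units; beyond the scatter) shows that a change at a substituent on the pendant ring can move the number a great deal, but there cyano replaced chloro. The step of a 1.5-fold lower number from compound 1 to compound 3 (0.17 log units; within the scatter) shows that a change of halogen on that ring, together with the added methyl, moved the number only within the scatter. On this basis a step of no size beyond the scatter is expected in this assay, with at most a slight lowering, a 1.2-fold lower number from compound 3 to compound 4 (0.09 log units; within the scatter).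

Compound 4 is therefore estimated at 600 nM, within a range from 250 nM to 1500 nM.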

Compound 4, half-maximal inhibitory concentration: 1100 nM
Compound 4: middle estimate off by 1.8-fold (0.26 log units), on the low side, within the range that was stated.
By their numbers in this assay, from the lowest: compounds 3, 1 and 4 (each within the scatter of the next); then compound 2.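

In this assay, among the compounds shown here, the exchange of fluoro for chloro, on an aromatic carbon para to a methyl group and meta to a large group, is the first direct halogen swap at this position, and a 1.5-fold higher number from compound 3 to compound 4 (0.17 log units; within the scatter) leaves no order to claim between the two halogens. The 5-chloro-2-methylphenyl group also stands within the scatter of the 2-chlorophenyl group, with no change at the digits printed from compound 1 to compound 4 (within the scatter) at the digits printed, whereas a 29-fold lower number from compound 2 to compound 4 (1.46 log units; beyond the scatter) is large, so that among these four compounds only the 2-cyanophenyl compound stands apart from the rest. Nothing available explains why the halogen swap stays within the scatter or why the nitrile-bearing compound differs so widely.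

Still open, from the compounds shown here alone, is whether a bromo, methoxy or trifluoromethyl group at this same position, or simple hydrogen in place of the halogen, would also stay within the scatter, or whether an amine or a carboxylic acid there would bring a large step like that of the nitrile. The compounds shown also leave open how the methyl group of the pendant ring acts on its own, and whether changes to the shared core would move the number further.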